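The source may hold more compounds than are shown below. What is called first, only, known or untested is meant among the compounds shown, and "the series" means these compounds.

Working notes on the series. Compound 3 `COc1ccc2c(C3CCc4ccc(F)cc43)ncnc2c1OC` gives 38 nM in an assay on isolated protein for inhibition of dual specificity calcium/calmodulin-dependent 3',5'-cyclic nucleotide phosphodiesterase 1B (Homo sapiens) (a lower number here means a stronger inhibitor, a higher number a weaker inhibitor), and stands second highest of the three measured numbers; compound 1 `COc1ccc2c(C3CCc4ccc(Cl)cc43)ncnc2c1OC` gives 4 nM and compound 2 `COc1cc2ncnc(C3CCc4ccc(Cl)cc43)c2cc1OC` gives 83 nM. The change toward compound 4 `COc1ccc2c(C3CCc4ccc(Br)cc43)ncnc2c1OC` is bromo in place of fluoro on an aromatic carbon. Going by the values given here, only one measured step bears on it: the halogen swap in the same place gave a 9.5-fold higher number from compound 1 to compound 3 (0.98 log units; beyond the scatter), so a heavier halogen went with the lower number, though no compound shows bromo yet. Compound 4 is therefore expected to return toward the number of compound 1, with a 9.5-fold lower number from compound 3 to compound 4 (0.98 log units; beyond the scatter) estimated, the number falling and beyond the scatter. The estimate for compound 4 in this assay is 4 nM, with a range of 1.3 nM to 12 nM.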

Compound 4, half-maximal inhibitory concentration: 8 nM
Compound 4: the middle estimate sits 2.0-fold (0.30 log units) below what was measured, and the stated range covers the measured number.
By their numbers in this assay, from the lowest: compounds 1 and 4 (each within the scatter of the next); then compound 3; then compound 2.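

On this aromatic carbon, bromo in place of fluoro gives a 4.8-fold lower number from compound 3 to compound 4 (0.68 log units; beyond the scatter) in this assay and so confirms that the fluoro compound stands apart. Bromo in place of chloro gives a 2.0-fold higher number from compound 1 to compound 4 (0.30 log units; within the scatter) and shows no difference that can be read between these two halogens. Nothing measured here accounts for either step.

Still open, as far as these compounds go, is how a nitrile, an amine or a methyl group on this carbon would compare with the halogens. Also open, from the compounds shown here alone, is whether the bromo and fluoro step holds on the core of compound 2.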